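The compounds below may be only part of what the source reports. "The series", "measured", "known", "first", "only" and "open" are said of these compounds alone.

Values in an ADME assay on cells (Hepatocyte, Mus musculus) for metabolic stability, with a stated time of 30 min; a lower number here means that less of the compound is left, a higher number that more of the compound is left:
- compound 1 `CS(=O)(=O)NC1CCC(CN2CCN(c3cc(=O)c4cc(C(F)(F)F)cc([N+](=O)[O-])c4s3)CC2)CC1`: 111%
- compound 2 `O=c1cc(N2CCN(CC3CCC(NS(=O)(=O)c4ccccc4)CC3)CC2)sc2c([N+](=O)[O-])cc(C(F)(F)F)cc12`: 95.3%
- compound 3 `O=C(NC1CCC(CN2CCN(c3cc(=O)c4cc(C(F)(F)F)cc([N+](=O)[O-])c4s3)CC2)CC1)c1ccccc1`: 90.6%

Compound 2 has one close neighbour and one distant one: a number 4.7 percentage points lower from compound 2 to compound 3 (within the scatter), and a number 15.7 percentage points lower from compound 1 to compound 2 (beyond the scatter).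

Compound 4 `O=C(OC1CCC(CN2CCN(c3cc(=O)c4cc(C(F)(F)F)cc([N+](=O)[O-])c4s3)CC2)CC1)C1CCCCC1` has (cyclohexylcarbonyl)oxy in place of (phenylsulfonyl)amino on a saturated ring carbon.

For the measured compounds named here, no measured compound carries this group, so the evidence is indirect. The swap to benzoyl gave a number 4.7 percentage points lower from compound 2 to compound 3 (within the scatter), and the two modest steps, a number 15.7 percentage points lower from compound 1 to compound 2 (beyond the scatter) and a number 20.4 percentage points lower from compound 1 to compound 3 (beyond the scatter), both run downward. The expected step is modest and downward, a number 13.3 percentage points lower from compound 2 to compound 4 (beyond the scatter), though the estimate is loose.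

Compound 4 is estimated at 82%, within an expected range of 58% to 105%.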

Compound 4, percent of the compound remaining: 1.2%
Compound 4: the middle estimate sits 80.8 percentage points above what was measured; measured number below the stated range.
By their numbers in this assay, from the lowest: compound 4; then compounds 3 and 2 (each within the scatter of the next); then compound 1.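

In this assay, for the compounds shown here, this position tolerates far less than the earlier compounds suggested: a number 94.1 percentage points lower from compound 2 to compound 4 (beyond the scatter), a number 89.4 percentage points lower from compound 3 to compound 4 (beyond the scatter) and a number 109.8 percentage points lower from compound 1 to compound 4 (beyond the scatter). Earlier changes among the nitrogen-linked groups gave modest steps at most, whereas (cyclohexylcarbonyl)oxy gives a large step in all three comparisons. No measurement shown here accounts for this drop.

Compound 4 changes both the atom linking the group to the saturated ring and the terminal ring, so these two changes remain unseparated. A cyclohexanecarboxamido group or a benzoyloxy group on the same ring carbon would show which change carries the step.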